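Swapping Allyloxy for Propyl on a Carbonyl Carbon

This account rests on a few compounds, and the source may have more. Where it says the series, first, only, none or still open, it means among the compounds named here.

In a functional assay on MDA-MB-231 cells (Homo sapiens) for inhibition, read by MTT assay, with a stated time of 96 h (on this read-out lower numbers stand for stronger inhibition of growth and higher numbers for weaker inhibition of growth), compound 3 `C=CCOC(=O)SCCCCCCNC(=O)c1cc(-c2ccncc2)n[nH]1` gives 36000 nM, and compound 1 `O=C(OCc1ccccc1)SCCCCCCNC(=O)c1cc(-c2ccncc2)n[nH]1` gives 24700 nM. These two values sit close together, with a 1.5-fold higher number from compound 1 to compound 3 (0.16 log units; within the scatter). Compound 2 `CC(C)C(=O)SCCCCCCNC(=O)c1cc(-c2ccncc2)n[nH]1` gives > 50000 nM in this assay, which is a limit of the assay and not a number.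

Compound 4 `CCCC(=O)SCCCCCCNC(=O)c1cc(-c2ccncc2)n[nH]1` carries propyl in place of allyloxy on a carbonyl carbon. Compound 2 is its nearest measured relative, since it also has a plain carbon group on that carbonyl carbon. For the measured compounds named here, two measured steps bear on the change. One is an at least 1.3-fold lower number from compound 2 to compound 3 (0.14 log units; that floor lies within the scatter), and the other is an at least 2.0-fold higher number from compound 1 to compound 2 (0.30 log units; that floor lies within the scatter). Both are floors only, and both lie within the scatter, so they point weakly towards a higher number when the oxygen-linked group leaves. The expected change is therefore small and upward, and it is not expected to clear the scatter: the estimated step is a 1.3-fold higher number from compound 3 to compound 4 (0.12 log units; within the scatter). A reading that reports only a limit is also quite possible. The estimate for compound 4 is 48000 nM, with an expected range of 25000 nM to 85000 nM.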

Compound 4, concentration for 50% growth inhibition: > 50000 nM
Compound 4: only a limit was reported; the forecaster's own chance of this, stated with the estimate: 50%; middle value at least 1.0-fold (0.01 log units) away from the limit.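

With propyl on the carbonyl carbon, compound 4 ends at a limit of the assay and not a number, so both compounds with a plain carbon group there, compound 2 and compound 4, now give no measurable value: the limit of > 50000 nM in this assay, at which 2 of the 4 values shown sit.

Replacing the oxygen-linked groups gives an at least 1.3-fold higher number from compound 3 to compound 4 (0.14 log units; that floor lies within the scatter) and an at least 2.0-fold higher number from compound 1 to compound 4 (0.30 log units; that floor lies within the scatter); these are only floors, so neither shows a real loss of growth inhibition. The step from compound 2 to compound 4 cannot be read, and straight propyl and branched isopropyl therefore cannot be told apart here.

On these data alone, how far above the limit compound 2 and compound 4 truly lie remains unknown. Also open, as far as these compounds go, is how this carbonyl carbon would respond to an amine, such as a dimethylamino group, or to a longer chain, such as octyl.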